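From a Chloroethyl Chain to a Sulfonamide Arm

The source may report more compounds than this note shows. Statements on the series, on what has been measured and on what is new or still open speak of the compounds shown alone.

Three analogues sharing one core have been measured in a functional assay on SW-620 cells (Homo sapiens) for antiproliferative activity, read by MTT assay, with a stated time of 72 h; a lower number here means a stronger inhibitor, a higher number a weaker inhibitor. Compound 1 `CCCCCCCCCCc1cn(C[C@H](O)[C@H]2OC(=O)C(OCc3ccccc3)=C2OCc2ccccc2)nn1` gives 45200 nM. Compound 2 `O=C1O[C@H]([C@@H](O)Cn2cc(CNS(=O)(=O)c3ccc(Cl)cc3)nn2)C(OCc2ccccc2)=C1OCc1ccccc1` gives 18000 nM. Compound 3 `O=C1O[C@H]([C@@H](O)Cn2cc(CCCCl)nn2)C(OCc2ccccc2)=C1OCc1ccccc1` gives 68500 nM, the highest of the three numbers: the step of a 1.5-fold higher number from compound 1 to compound 3 (0.18 log units; within the scatter) lies within the scatter, while the step of a 3.8-fold higher number from compound 2 to compound 3 (0.58 log units; beyond the scatter) lies beyond it.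

Compound 4 `O=C1O[C@H]([C@@H](O)Cn2cc(CNS(=O)(=O)c3ccc(Cl)cc3F)nn2)C(OCc2ccccc2)=C1OCc1ccccc1` is the next case, differing from compound 3 by ((4-chloro-2-fluorophenyl)sulfonyl)amino in place of 2-chloroethyl on a saturated chain carbon bound to an aromatic carbon. For the measured compounds named here, the closest precedent is the step of a 3.8-fold higher number from compound 2 to compound 3 (0.58 log units; beyond the scatter), read in reverse: the arm entering compound 4 matches that of compound 2 apart from the fluorine. The step of a 2.5-fold lower number from compound 1 to compound 2 (0.40 log units; beyond the scatter) points the same way, toward a lower number when a sulfonamide arm replaces a plain chain. Nothing measured shows what the added fluorine contributes on its own. A lower number is expected for compound 4, a step of about a 3.8-fold lower number from compound 3 to compound 4 (0.58 log units; beyond the scatter). Compound 4 is estimated at 18000 nM, with a range from 7000 nM to 45000 nM.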

Compound 4, half-maximal inhibitory concentration: 42400 nM
For compound 4 the middle estimate is 2.4-fold (0.37 log units) below the measured one; measured number inside the range.
By their numbers in this assay, from the lowest: compound 2; then compounds 4, 1 and 3 (each within the scatter of the next).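

Fluoro in place of hydrogen on an aromatic carbon gives a 2.4-fold higher number from compound 2 to compound 4 (0.37 log units; beyond the scatter) in this assay, so one added atom on the aromatic ring of the sulfonamide arm is enough to shift the result by more than the scatter. With that fluorine present, the arm no longer stands apart from the plain chains, since a 1.6-fold lower number from compound 3 to compound 4 (0.21 log units; within the scatter) and a 1.1-fold lower number from compound 1 to compound 4 (0.03 log units; within the scatter) both lie within the scatter. A sulfonamide arm at this place therefore does not by itself give a lower number, and nothing available here explains what the fluorine does.

From the compounds shown here alone, whether a methyl or a methoxy group in place of that fluoro would give the same shift remains open. So does the outcome of an amide or a simple amine arm on the same saturated chain carbon.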